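Furan-3-yl for 3-methylphenyl on the cyclopropane of compound 3

A few compounds are considered here, and "the series" means these few. Any claim that something is new, unique, unknown or untested is made for them only; others in the source may bear on it.

Compound 1 `CC(C)[C@H](N)CN(C(=O)[C@@H]1C[C@H]1c1ccccc1)c1ccc(-c2ccccc2)cc1` — 1.1 nM
Compound 2 `CCC(CC)C(N)CCN(C(=O)[C@@H]1C[C@H]1c1ccccc1)c1ccc(-c2ccccc2)cc1` — 2 nM
Compound 3 `CC[C@H](C)[C@H](N)CN(C(=O)[C@@H]1C[C@H]1c1cccc(C)c1)c1ccc(-c2ccccc2)cc1` — 1200 nM
Compound 4 `CC[C@H](C)[C@H](N)CN(C(=O)[C@@H]1C[C@H]1c1ccoc1)c1ccc(-c2ccccc2)cc1` — not yet measured

In a functional assay for agonist activity at G protein-coupled receptor 88 (Homo sapiens), read by HTRF and cAMP accumulation (on this read-out higher numbers stand for an effect only at larger amounts of compound and lower numbers for an effect already at smaller amounts), compound 3 gives 1200 nM, the highest of the three numbers. Compound 2 gives 2 nM and compound 1 gives 1.1 nM; both gaps to compound 3 lie beyond the scatter. Among the measured compounds shown here, the only measured step, a 1.8-fold higher number from compound 1 to compound 2 (0.26 log units; within the scatter), concerns the 1-amino-2-methylpropyl chain on the amide-type nitrogen, not the ring on the cyclopropane, and lies within the scatter.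

Compound 4 differs from compound 3 by furan-3-yl in place of 3-methylphenyl on a saturated ring carbon. For the measured compounds named here, no measured pair shows this change. Going by the values given here, compound 3 is the only compound bearing 3-methylphenyl and none bears furan-3-yl. Compounds 1 and 2 carry phenyl on the cyclopropane but also differ from compound 3 in the chain on the amide-type nitrogen, so their gap to compound 3 cannot be assigned to the ring alone. Among the compounds with values here, the data therefore give no direction for this step, and the expected step of a 1.3-fold higher number from compound 3 to compound 4 (0.10 log units; within the scatter) is set close to no change, with wide uncertainty. For compound 4 in this assay the estimate is 1500 nM, expected to fall between 250 nM and 9000 nM.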

Compound 4, half-maximal effective concentration: 580 nM
Compound 4: middle estimate off by 2.6-fold (0.41 log units), on the high side; the range from low to high includes it.
By their numbers in this assay, from the lowest: compounds 1 and 2 (each within the scatter of the next); then compound 4; then compound 3.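

In this assay, among the compounds shown here, furan-3-yl in place of 3-methylphenyl on the cyclopropane gives a 2.1-fold lower number from compound 3 to compound 4 (0.32 log units; beyond the scatter), the first reading at this position with the rest of the structure held constant. The step is modest, but it shows that the number at this position responds to the ring it carries, and that a five-membered aromatic ring with 1 hetero atom is accepted here without a rise in the number. The change replaces 7 heavy atoms with 5 and adds a hydrogen-bond acceptor in a single exchange, and nothing available explains the step.

For the compounds shown here, the single step does not separate the loss of the methyl group from the change of ring size or the entry of the ring oxygen, so unsubstituted phenyl, furan-2-yl and thiophen-3-yl on the cyclopropane, each with the chain of compound 3, remain the informative comparisons. Also open, on these data alone, is how much of the gap between compound 3 and compounds 1 and 2 belongs to the ring and how much to the chain, since those compounds differ from compound 3 in both places.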